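This account rests on a few compounds, and the source may have more. Where it says the series, first, only, none or still open, it means among the compounds named here.

In a functional assay on MCF7 cells (Homo sapiens) for antiproliferative activity, read by MTT assay, with a stated time of 24 h (on this read-out lower numbers stand for stronger inhibition and higher numbers for weaker inhibition), compound 3 `COc1ccc(S(=O)(=O)n2c(-c3cn(-c4ccccc4)nc3-c3ccc(C(F)(F)F)cc3)nc3ccccc32)cc1` gives 420 nM and compound 2 `Cc1ccc(C)c(S(=O)(=O)n2c(-c3cn(-c4ccccc4)nc3-c3ccc(F)cc3)nc3ccccc32)c1` gives 430 nM, two values within the scatter of each other. Compound 1 `FC(F)(F)c1ccc(-c2nn(-c3ccccc3)cc2-c2nc3ccccc3[nH]2)cc1`, without a sulfonyl group on the aromatic nitrogen, gives the higher 6330 nM.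

The next structure is compound 4 `Cc1ccc(C)c(S(=O)(=O)n2c(-c3cn(-c4ccccc4)nc3-c3ccc(C(F)(F)F)cc3)nc3ccccc32)c1`, with 2,5-dimethylphenyl in place of 4-methoxyphenyl on a sulfonyl sulfur.

For the measured compounds named here, the only measured step, a 15-fold lower number from compound 1 to compound 3 (1.18 log units; beyond the scatter), is large, but it records (4-methoxyphenyl)sulfonyl in place of hydrogen on an aromatic nitrogen. Going by the values given here, it does not compare one sulfonyl group with another, and no measured step isolates the present exchange. The closest evidence is compound 2, which already carries the 2,5-dimethylphenyl group on its sulfonyl sulfur and, at 430 nM, matches compound 3 within the scatter, although it differs from compound 4 elsewhere.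

In this assay, no change beyond the scatter is therefore expected, and the estimated step is a 1.1-fold lower number from compound 3 to compound 4 (0.02 log units; within the scatter). The expected value for compound 4 is 400 nM, within an estimated range of 190 nM to 850 nM.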

Compound 4, half-maximal inhibitory concentration: 170 nM
The estimate for compound 4 lay 2.4-fold (0.37 log units) above the measured number, and the stated range ends above it.
By their numbers in this assay, from the lowest: compound 4; then compounds 3 and 2 (each within the scatter of the next); then compound 1.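

In this assay, the sulfonyl aryl group is a position where an exchange moves the number: 2,5-dimethylphenyl in place of 4-methoxyphenyl on a sulfonyl sulfur gives a 2.5-fold lower number from compound 3 to compound 4 (0.39 log units; beyond the scatter) and so goes beyond the scatter, though only modestly. With the (2,5-dimethylphenyl)sulfonyl group held fixed, trifluoromethyl in place of fluoro on an aromatic carbon gives a 2.5-fold lower number from compound 2 to compound 4 (0.40 log units; beyond the scatter) and the N-sulfonyl gain also appears with this second group, since (2,5-dimethylphenyl)sulfonyl in place of hydrogen on an aromatic nitrogen gives a 37-fold lower number from compound 1 to compound 4 (1.57 log units; beyond the scatter) as a large step. No supporting measurement bears on what lies behind these steps.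

On these data alone, whether a single methyl group, a chloro group or an amine on the sulfonyl phenyl ring would lower the number further remains open, as does the effect of replacing that ring with a simple methyl group on the sulfonyl sulfur. As far as these compounds go, whether the trifluoromethyl step holds with (4-methoxyphenyl)sulfonyl also remains open.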